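The compounds below may be only part of what the source reports. "The series", "measured", "known", "first", "only" and "open" are said of these compounds alone.

For the measured compounds named here, compound 3 `CC(C)n1nc(-c2cccnc2)c2ccccc2c1=O` gives the highest number of the three measured members. In an assay on isolated protein (Oryctolagus cuniculus) with Thromboxane-A synthase (Homo sapiens) as the target, tested at 1 uM (a lower number here means less inhibition, a higher number more inhibition at the concentration tested (going by the name of the read-out)), compound 3 gives 87%. Its nearest neighbour is compound 2 `CCCn1nc(-c2cccnc2)c2ccccc2c1=O`, which in this assay gives 86%; the difference, a number 1 percentage points higher from compound 2 to compound 3 (within the scatter), is within the scatter, so the two cannot be ranked against each other. Compound 1 `Cn1nc(-c2cccnc2)c2ccccc2c1=O`, which in this assay gives 63%, lies clearly lower than both.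

Compound 4 `CCCCn1nc(-c2cccnc2)c2ccccc2c1=O` has not yet been measured. It differs from compound 3 in one place: butyl in place of isopropyl on an aromatic nitrogen. So the chain on the aromatic nitrogen grows by one carbon and loses its branching.

Going by the values given here, three measured steps bear on this. Enlarging the group on the aromatic nitrogen from methyl brought a number 23 percentage points higher from compound 1 to compound 2 (beyond the scatter) and a number 24 percentage points higher from compound 1 to compound 3 (beyond the scatter), both beyond the scatter. Swapping one three-carbon group for another, however, brought only a number 1 percentage points higher from compound 2 to compound 3 (within the scatter), within the scatter. The gain therefore appears to come with leaving methyl behind, and further reshaping of the chain has not mattered so far.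

The expected step is a number 1 percentage points lower from compound 3 to compound 4 (within the scatter), essentially none beyond the scatter. Compound 4 is estimated at 86%, likely between 74% and 95%.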

Compound 4, a percentage reported as inhibition, at one concentration (the size of the read-out at that concentration, not a potency): 91%
The estimate for compound 4 lay 5 percentage points below the measured number, and the stated range covers the measured number.
By their numbers in this assay, from the lowest: compound 1; then compounds 2, 3 and 4 (each within the scatter of the next).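

In this assay, replacing the branched isopropyl with the longer, unbranched butyl gives a number 4 percentage points higher from compound 3 to compound 4 (within the scatter) and extending propyl to butyl gives a number 5 percentage points higher from compound 2 to compound 4 (within the scatter) so neither change separates compound 4 from the propyl and isopropyl compounds. The comparison with the methyl compound gives a number 28 percentage points higher from compound 1 to compound 4 (beyond the scatter) and this shows that the separation from methyl seen with propyl and isopropyl also holds for butyl, while the three larger groups cannot be ranked against one another. No measurement offered here explains why these groups stand apart from methyl.

The compounds shown leave open whether the same level holds for a longer chain such as hexyl or for a ring-bearing group such as benzyl, and whether ethyl already stands apart from methyl. They also leave open what happens when the chain ends in an amine or a carboxylic acid, and how the larger groups would rank in a read-out taken at lower concentrations or as a full potency measurement.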